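A few compounds are considered here, and "the series" means these few. Any claim that something is new, unique, unknown or untested is made for them only; others in the source may bear on it.

Of the compounds shown here, three have so far been read in a functional assay on COLO 205 cells (Homo sapiens) for inhibition, read by sulforhodamine B assay, with a stated time of 48 h, tested at 50 uM (on this read-out lower numbers stand for less inhibition of growth and higher numbers for more inhibition of growth at the one concentration tested), at the single concentration tested. There compound 1 `COc1cc(/C=C/C(=O)/C=C/c2cccc3ccccc23)ccc1OCc1cn(CCCOc2cc(=O)oc3ccccc23)nn1` reaches 64% while compound 2 `COc1cccc(/C=C/C(=O)/C=C/c2ccc(OCc3cn(CCCCCOc4cc(=O)oc5ccccc45)nn3)c(OC)c2)c1` reaches 34% and compound 3 `COc1cc(/C=C/C(=O)/C=C/c2ccccc2)ccc1OCc1cn(CCCCOc2cc(=O)oc3ccccc23)nn1` reaches 31% on the same scale. Compound 2 therefore lies within the scatter of compound 3 and well short of compound 1, a gap beyond the scatter.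

The next compound to be read is compound 4 `COc1ccc(/C=C/C(=O)/C=C/c2ccc(OCc3cn(CCCCCOc4cc(=O)oc5ccccc45)nn3)c(OC)c2)cc1` which has the same atoms as compound 2, joined differently: 4-methoxyphenyl in place of 3-methoxyphenyl on a double-bonded chain carbon bound to a double-bonded chain carbon is the whole difference. Going by the values given here, no measured pair here differs in one place, so the data offer no step to serve as a guide. The counts of heavy atoms and hydrogen-bond acceptors stay the same. In this assay compound 2 stands at 34% as the starting point. No change beyond the scatter is expected from there. The estimated step is a number 2 percentage points higher from compound 2 to compound 4 (within the scatter) and so stays within the scatter. For compound 4 the expected value is 36% with an estimated range from 20% to 55% for the coming measurement.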

Compound 4, percent growth inhibition at one concentration: 30%
For compound 4 the middle estimate is 6 percentage points above the measured one, and the stated range covers the measured number.
By their numbers in this assay, from the lowest: compounds 4, 3 and 2 (each within the scatter of the next); then compound 1.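

In this assay, putting 4-methoxyphenyl in place of 3-methoxyphenyl on a double-bonded chain carbon bound to a double-bonded chain carbon gives a number 4 percentage points lower from compound 2 to compound 4 (within the scatter). Going by these compounds alone, this is the first comparison between compounds that differ in one place, and it shows that, at the one concentration tested, this read-out does not separate the two methoxyphenyl groups at this position. Nothing measured here bears on the reason for this result.

Going by these compounds, what an amine or a carboxylic acid would do in place of the methoxy group at this position remains open. On these data alone, it is also open whether the two methoxyphenyl compounds would still read alike with a longer chain in the linker, or with the naphthalene-bearing end of compound 1.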